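This account rests on a few compounds, and the source may have more. Where it says the series, first, only, none or still open, it means among the compounds named here.

Compound 1 `CC(C(=O)NCc1ccc(C(F)(F)F)nc1)c1ccc(NS(C)(=O)=O)c(F)c1` is the starting point of this step. In a functional assay on CHO-K1 cells for antagonist activity at transient receptor potential cation channel subfamily V member 1 (Homo sapiens), read by FLIPR (a higher number here means a weaker inhibitor, a lower number a stronger inhibitor), compound 1 gives "not active" (no number reported), so no single number places it among the others. Two related compounds carry a substituent at the same position of the shared core: compound 2 `CCCCNc1nc(C(F)(F)F)ccc1CNC(=O)C(C)c1ccc(NS(C)(=O)=O)c(F)c1` gives 293 nM in this assay, and compound 3 `CC(C(=O)NCc1ccc(C(F)(F)F)nc1N1CCC(Cc2cc(F)cc(F)c2)CC1)c1ccc(NS(C)(=O)=O)c(F)c1` gives 24 nM. Compound 4 `CC(C(=O)NCc1ccc(C(F)(F)F)nc1N1CCC(O)CC1)c1ccc(NS(C)(=O)=O)c(F)c1` is not yet measured. Compound 4 differs from compound 1 as follows: 4-hydroxypiperidin-1-yl in place of hydrogen on an aromatic carbon. Since compound 1 has no number, no step size can be stated, but the move from an unsubstituted core to a substituted one is expected to bring compound 4 into measurable inhibition. Compound 4 is estimated at 300 nM in this assay, within the range 80 nM to 1500 nM.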

Compound 4, half-maximal inhibitory concentration: "not active" (no number reported)
No number was reported for compound 4; no gap can be computed for the estimate.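

Neither compound 1 nor compound 4 has a number in this assay, so no step can be read between them. No evidence shown bears on this result. The compounds shown leave open how far 4-hydroxypiperidin-1-yl in place of hydrogen changes inhibition, if at all.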